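This account rests on a few compounds, and the source may have more. Where it says the series, first, only, none or still open, it means among the compounds named here.

The set holds three measured compounds and one that awaits measurement. Compound 1 `Cc1ccc(C(=O)CCc2nnc(-c3ccc([N+](=O)[O-])cc3)o2)cc1` carries a nitro group; in a functional assay on the whole organism (strain Wistar) for inhibition, with Rattus norvegicus as the target, with stated times of 30 min and 2 h, at a dose of 20 mg/kg by the oral route (a higher number here means more inhibition at the dose given (going by the name of the read-out), a lower number less inhibition), compound 1 gives 52%. Compound 2 `COc1ccc(-c2nnc(CCC(=O)c3ccc(C)cc3)o2)cc1` differs from compound 1 by methoxy in place of nitro on an aromatic carbon, and in this assay compound 2 gives 69.3%, the step being a number 17.3 percentage points higher from compound 1 to compound 2 (beyond the scatter). Compound 3 `Cc1ccc(C(=O)CCc2nnc(-c3ccc([N+](=O)[O-])cc3)o2)c(C)c1` differs from compound 1 by methyl in place of hydrogen on an aromatic carbon; in this assay compound 3 gives 40%, the lowest of the three numbers, with the step of a number 12 percentage points lower from compound 1 to compound 3 (beyond the scatter). Compound 4 `COc1ccc(-c2nnc(CCC(=O)c3ccc(C)cc3C)o2)cc1` has not been measured. It differs from compound 3 by methoxy in place of nitro on an aromatic carbon, the same change that is seen once already, and the place of the change is described in the same words in both pairs; the two cores differ only by the methyl group just named. Going by the values given here, the step from compound 3 to compound 4 in this assay is expected to be a number 17 percentage points higher from compound 3 to compound 4 (beyond the scatter), resting on the single earlier step of a number 17.3 percentage points higher from compound 1 to compound 2 (beyond the scatter). Compound 4 is therefore expected to give about 57% in this assay, most likely between 42% and 72%.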

Compound 4, a percentage reported as inhibition, in the whole organism at one dose (the size of the read-out at that dose, not a potency): 62.7%
Estimate against measurement, compound 4: 5.7 percentage points below; low and high end bracket the measured number.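

In this assay, methoxy in place of nitro on an aromatic carbon gives, on the core of compound 3, a number 22.7 percentage points higher from compound 3 to compound 4 (beyond the scatter), and this agrees with the step seen earlier on the core of compound 1: the same change on two cores in this assay, a number 17.3 percentage points higher (beyond the scatter) from compound 1 to compound 2 and a number 22.7 percentage points higher (beyond the scatter) from compound 3 to compound 4, 5.4 percentage points apart, within the scatter of two such steps. Methyl in place of hydrogen on an aromatic carbon, read on the methoxy compounds, gives a number 6.6 percentage points lower from compound 2 to compound 4 (within the scatter), and that step does not differ from its counterpart on the nitro compounds: the same change on two cores in this assay, a number 12 percentage points lower (beyond the scatter) from compound 1 to compound 3 and a number 6.6 percentage points lower (within the scatter) from compound 2 to compound 4, 5.4 percentage points apart, within the scatter of two such steps. This shows that the change carried over between two cores separated by a single methyl group, at one dose; it does not show that it would carry over to cores that differ more widely, and it says nothing about potency.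

The compounds shown leave open how chloro, hydroxyl or an amine in place of nitro or methoxy would fare on these cores. They also leave open what a longer chain in place of the present one would do to either step.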